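A few compounds are considered here, and "the series" means these few. Any claim that something is new, unique, unknown or untested is made for them only; others in the source may bear on it.

The compounds share one core, seen in compound 1 `Brc1cccc(/C=C/c2nnc(-c3ccc4c(c3)OCCO4)o2)c1`, which carries a 3-bromophenyl group at one end. In a functional assay on HUVEC cells (Homo sapiens) for antiproliferative activity, read by MTT assay, with a stated time of 48 h (on this read-out higher numbers stand for weaker inhibition and lower numbers for stronger inhibition), compound 1 gives 13500 nM. Compound 2 `COc1ccc(/C=C/c2nnc(-c3ccc4c(c3)OCCO4)o2)cc1` carries a 4-methoxyphenyl group instead. In this assay compound 2 gives only a limit, > 50000 nM. Compound 3 `COc1cccc(/C=C/c2nnc(-c3ccc4c(c3)OCCO4)o2)c1` carries a 3-methoxyphenyl group. For compound 3 this assay likewise gives only a limit, > 50000 nM. Compound 3 thus stands at the weak end of the numbers shown, at the limit of > 50000 nM in this assay, at which 2 of the 3 values shown sit, and nothing separates it from compound 2: the step that the two limits leave unreadable from compound 2 to compound 3. Exchanging the bromo of compound 1 for methoxy gave an at least 3.7-fold higher number from compound 1 to compound 3 (0.56 log units; beyond the scatter), the weakening that brought compound 3 to that limit.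

Compound 4 `Fc1cccc(/C=C/c2nnc(-c3ccc4c(c3)OCCO4)o2)c1` differs from compound 3 in one place: fluoro in place of methoxy on an aromatic carbon. Among the compounds with values here, this brings a halogen back to where compound 1 carries bromo, and that earlier exchange, an at least 3.7-fold higher number from compound 1 to compound 3 (0.56 log units; beyond the scatter), is the one measured step that bears on it, read in reverse. A partial reversal of that size is expected in this assay, so the step of an at least 2.0-fold lower number from compound 3 to compound 4 (0.30 log units; that floor lies within the scatter) is estimated, towards stronger inhibition, though with a real chance that only a limit is again reported. Compound 4 is therefore expected to give about 25000 nM, within a range from 8000 nM to 60000 nM.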

Compound 4, half-maximal inhibitory concentration: 3530 nM
For compound 4 the middle estimate is 7.1-fold (0.85 log units) above the measured one; measured number outside the range, below it.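

At the aromatic carbon meta to a large group, the choice of substituent matters more than compound 1 and compound 3 could show: in this assay, fluoro in place of methoxy gave an at least 14-fold lower number from compound 3 to compound 4 (1.15 log units; beyond the scatter), a large move towards stronger inhibition. The 3-fluorophenyl group in place of 4-methoxyphenyl gave a step of similar reach, an at least 14-fold lower number from compound 2 to compound 4 (1.15 log units; beyond the scatter), so compound 4 stands well clear of both methoxy compounds, although the two limits leave the step between those compounds themselves unreadable. Fluoro also improves on bromo, with a 3.8-fold lower number from compound 1 to compound 4 (0.58 log units; beyond the scatter), so the two halogens are not interchangeable here, and compound 4, the strongest of the four, lies furthest from the compounds held at a limit rather than a number: the limit of > 50000 nM in this assay, at which 2 of the 4 values shown sit.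

On these data alone, whether the order of fluoro, bromo and methoxy extends to other groups in the same place, such as chloro, an amine or a nitrile, stays open. These values also give no cause for the gain with fluoro, so they cannot say what makes this small group work so much better than methoxy.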